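The source may report more compounds than this note shows. Statements on the series, on what has been measured and on what is new or still open speak of the compounds shown alone.

Of the compounds shown here, three of one series have so far been measured in a functional assay on Hs-578T cells (Homo sapiens) for inhibition, read by sulforhodamine B assay, with a stated time of 48 h; on this read-out higher numbers stand for weaker inhibition of growth and lower numbers for stronger inhibition of growth. Compound 1 `N=C(N)c1ccc(-c2ccc(-c3cc(Cl)cc(Cl)c3)s2)cc1` gives 2050 nM. Compound 2 `N=C(N)c1ccc(-c2ccc(-c3ccc(Cl)cc3)s2)cc1F` gives 726 nM. Compound 3 `COc1cc(OC)cc(-c2ccc(-c3ccc(C(=N)N)c(F)c3)s2)c1` gives 1470 nM. Among these three, compound 2 stands at the lowest number and so inhibits growth most strongly; its gap to compound 3, the nearest, and its gap to compound 1, the furthest, both lie beyond the usual scatter of repeated measurements.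

The next compound, compound 4 `N=C(N)c1ccc(-c2ccc(-c3ccccc3)s2)cc1F`, has not yet been measured in this assay. It differs from compound 2 in one place: hydrogen in place of chloro on an aromatic carbon. The chloro that leaves sits on an aromatic carbon of a six-membered aromatic ring of carbon only, para to a large group, and only a hydrogen atom takes its place.

Among the compounds with values here, no pair of measured compounds differs in one place alone, so no measured step shows what this change by itself does. What the numbers show is that compound 2, which carries a single chloro, stands lowest, while compound 1, which carries two chloro groups, and compound 3, which carries two methoxy groups, give higher numbers. The step is expected to be a modest rise in the number, a 1.7-fold higher number from compound 2 to compound 4 (0.22 log units; within the scatter), a little beyond the scatter. Compound 4 is therefore estimated to give about 1200 nM in this assay, most likely between 500 nM and 2800 nM.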

Compound 4, concentration for 50% growth inhibition: 10900 nM
The estimate for compound 4 lay 9.1-fold (0.96 log units) below the measured number, outside the stated range (above it).
By their numbers in this assay, from the lowest: compound 2; then compounds 3 and 1 (each within the scatter of the next); then compound 4.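

In this assay, hydrogen in place of chloro on an aromatic carbon gives a 15-fold higher number from compound 2 to compound 4 (1.18 log units; beyond the scatter), a large loss of growth inhibition from one change. Within the data shown here, this is the first step that isolates a single change, and it shows that the chloro on this six-membered aromatic ring, para to a large group, is far from a passive passenger: much of the inhibition seen with compound 2 depends on this one atom, since the rest of the molecule stays the same. Nothing measured here explains why a single chloro counts for so much.

The compounds shown carry only chloro or hydrogen at this place, so it remains open whether a bromo, a methyl or an amine there would keep the inhibition of compound 2 or lose it as compound 4 does. Compound 1 and compound 3 each differ from compound 2 in more than one place, so they cannot show whether moving the chloro elsewhere on the ring, or adding a second group to it, helps or harms growth inhibition.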